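This account rests on a few compounds, and the source may have more. Where it says the series, first, only, none or still open, it means among the compounds named here.

Two compounds share one core and differ only in the group carried on an aromatic carbon of a six-membered aromatic ring of carbon only. Compound 1 `O=C(O)c1ccc2noc(-c3cccc(C(F)(F)F)c3)c2c1` carries trifluoromethyl there, and in an assay for inhibition of inositol hexakisphosphate kinase 2 (Homo sapiens), read by colorimetric assay, coupled enzyme assay and malachite green, with a stated time of 120 min, in the presence of a further agent that is not named here (on this read-out higher numbers stand for weaker inhibition and lower numbers for stronger inhibition), compound 1 gives 1460 nM. Compound 2 `O=C(O)c1ccc2noc(-c3cccc(-c4ccccc4)c3)c2c1` carries phenyl at that place, and in this assay compound 2 gives 130 nM. Among the measured compounds shown here, the one step in hand, an 11-fold lower number from compound 1 to compound 2 (1.05 log units; beyond the scatter), is large and lies beyond the scatter. For the measured compounds named here, compound 2 therefore holds the lower of the two numbers seen so far, with compound 1 as its only neighbour.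

Compound 3 `O=C(O)c1ccc2noc(-c3cccc(Oc4ccccc4)c3)c2c1` has not yet been measured. It differs from compound 2 by phenoxy in place of phenyl on an aromatic carbon. Going by the values given here, no measured step covers this exchange directly; the single step available, an 11-fold lower number from compound 1 to compound 2 (1.05 log units; beyond the scatter), shows that a large aromatic group at this place goes with a low number, but it says nothing about the phenoxy itself. Compound 3 is therefore expected to remain close to compound 2, with a step of a 1.5-fold higher number from compound 2 to compound 3 (0.19 log units; within the scatter) that may well stay within the scatter. The estimate for compound 3 in this assay is 200 nM, with a range from 60 nM to 700 nM.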

Compound 3, half-maximal inhibitory concentration: 130 nM
Compound 3: the middle estimate sits 1.5-fold (0.19 log units) above what was measured, within the range that was stated.
By their numbers in this assay, from the lowest: compounds 2 and 3 (each within the scatter of the next); then compound 1.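

In this assay, the exchange of phenyl for phenoxy leaves the read-out unmoved (no change at the digits printed from compound 2 to compound 3 (within the scatter)), so at this place, on an aromatic carbon and meta to a large group, the oxygen that enters with phenoxy, together with the hydrogen-bond acceptor counted for it, comes with no difference from phenyl. Set against trifluoromethyl, phenoxy repeats the large step first seen with phenyl (an 11-fold lower number from compound 1 to compound 3 (1.05 log units; beyond the scatter)), so among these three compounds the low number no longer rests on a single group: it appears with both groups that carry a six-membered aromatic ring of carbon only, and the one compound without such a ring, compound 1, stands apart from both. Nothing available explains why phenyl and phenoxy match here.

The compounds shown leave open whether this match would hold with an amine or a methylene as the link in place of the oxygen, or with a longer chain between the two rings. They also leave open whether a carboxylic acid or an amine on the outer ring, or a cyclohexyl group in place of that ring, would stay with compound 2 and compound 3 or fall back towards compound 1.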